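Swapping methoxy for fluoro at an assay limit

This account rests on a few compounds, and the source may have more. Where it says the series, first, only, none or still open, it means among the compounds named here.

Measured so far in a functional assay on A549 cells (Homo sapiens) for cytotoxicity, read by MTT assay, with a stated time of 72 h; on this read-out lower numbers stand for stronger inhibition and higher numbers for weaker inhibition:
- compound 1 `O=S(=O)(c1ccc(F)cc1)c1nc2ccccc2nc1N1CCCC1`: 31100 nM
- compound 2 `Cc1ccc(S(=O)(=O)c2nc3ccccc3nc2N2CCc3ccccc3C2)cc1`: > 50000 nM
- compound 3 `COc1ccc(S(=O)(=O)c2nc3ccccc3nc2N2CCc3ccccc3C2)cc1`: > 50000 nM

Compound 3 gives > 50000 nM, which is a limit and not a number. Compound 2 gives > 50000 nM, also a limit. Together they make up (the limit of > 50000 nM in this assay, at which 2 of the 3 values shown sit). Compound 4 `O=S(=O)(c1ccc(F)cc1)c1nc2ccccc2nc1N1CCc2ccccc2C1` differs from compound 3 in one place, with fluoro in place of methoxy on an aromatic carbon, para to a large group (fluoro in place of methoxy on an aromatic carbon).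

Among the measured compounds shown here, the only measured step between close neighbours is a step that the two limits leave unreadable from compound 2 to compound 3, so it offers no size to carry over. Compound 1 also carries the 4-fluorophenyl group and gives 31100 nM, but it differs from compound 4 elsewhere, so it is only a loose guide. In this assay, the expectation is therefore for weak activity near the limit, with any gain likely to be small. The estimated step is an at least 1.1-fold lower number from compound 3 to compound 4 (0.04 log units; that floor lies within the scatter). Compound 4 is expected at about 45000 nM, with an estimated range of 20000 nM to 90000 nM.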

Compound 4, half-maximal inhibitory concentration: 22900 nM
The estimate for compound 4 lay 2.0-fold (0.29 log units) above the measured number, within the range that was stated.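

In this assay, the change from 4-methoxyphenyl to 4-fluorophenyl gives the first readable result at this position, with an at least 2.1-fold lower number from compound 3 to compound 4 (0.33 log units; beyond the scatter) and, for fluoro in place of methyl, with an at least 2.1-fold lower number from compound 2 to compound 4 (0.33 log units; beyond the scatter). Both sizes are only floors, because compound 2 and compound 3 each sit at a limit of the assay: the limit of > 50000 nM in this assay, at which 2 of the 4 values shown sit. With the 4-fluorophenyl group kept, tetrahydroisoquinolin-2-yl in place of pyrrolidin-1-yl gives a 1.4-fold lower number from compound 1 to compound 4 (0.13 log units; within the scatter) and so makes no readable difference here.

The step between methyl and methoxy cannot be read, so those two groups stay unranked. From the compounds shown here alone, it also remains open whether this result is particular to fluoro or would extend to chloro, trifluoromethyl or a carboxylic acid on the same aromatic carbon.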